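Stability of a triazole side chain bearing an aminomethyl group

The compounds below may be only part of what the source reports. "The series", "measured", "known", "first", "only" and "open" are said of these compounds alone.

Measured so far:
compound 1 `CN(C[C@@H]1[C@H](NC(=O)/C(=N\OC(C)(C)C(=O)O)c2csc(N)n2)C(=O)N1S(=O)(=O)O)C(=O)CN`: 212 h
compound 2 `CC(C)(O/N=C(\C(=O)N[C@@H]1C(=O)N(S(=O)(=O)O)[C@@H]1CN1CCCC1=O)c1csc(N)n1)C(=O)O`: > 1000 h
compound 3 `CC(C)(O/N=C(\C(=O)N[C@@H]1C(=O)N(S(=O)(=O)O)[C@@H]1Cn1ccnn1)c1csc(N)n1)C(=O)O`: 257 h

In a physicochemical assay for metabolic stability, read by HPLC and mass spectrometry, in phosphate buffer, at 37 degrees C, at pH 7.4 (a lower number here means that the compound disappears faster, a higher number that the compound lasts longer), compound 3 gives 257 h, the highest of the two plain numbers shown; compound 1 sits close by, a difference within the scatter. Compound 2 reports only a limit of this assay, > 1000 h. Compound 4 `CC(C)(O/N=C(\C(=O)N[C@@H]1C(=O)N(S(=O)(=O)O)[C@@H]1Cn1ncnc1CN)c1csc(N)n1)C(=O)O` differs from compound 3 by a group of 7 heavy atoms (3 carbon, 4 nitrogen; one five-membered aromatic ring with 3 hetero atoms) in place of a group of 5 heavy atoms (2 carbon, 3 nitrogen; one five-membered aromatic ring with 3 hetero atoms), on a saturated chain carbon bound to a saturated ring carbon. Going by the values given here, the steps that bear on this are a 1.2-fold higher number from compound 1 to compound 3 (0.08 log units; within the scatter) and an at least 3.8-fold lower number from compound 2 to compound 3 (0.59 log units; beyond the scatter). Among the compounds with values here, only the step to compound 2 moved beyond the scatter, and compound 4 keeps a five-membered aromatic ring like compound 3, so no step beyond the scatter is expected: a 1.2-fold lower number from compound 3 to compound 4 (0.09 log units; within the scatter). Compound 4 is therefore estimated at 210 h, between 90 h and 500 h.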

Compound 4, half-life: > 37 h
Compound 4 ended at the assay's limit (the forecaster's own chance of this, stated with the estimate: 10%); the middle value is on the limit's open side.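

Compound 4 gives only a limit of the assay, > 37 h. Going by these compounds alone, no step from compound 1, compound 2 or compound 3 to compound 4 can be read. As far as these compounds go, what stays open is how the half-life of compound 4 compares with those of the other three.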